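Para-trifluoromethyl variant of a thiazole acetic acid series

The compounds below may be only part of what the source reports. "The series", "measured", "known", "first", "only" and "open" are said of these compounds alone.

Compound 1, `O=C(O)Cc1sc(C(c2ccccc2)c2ccccc2)nc1-c1ccc(F)cc1`, gives 8.7 nM in an in vitro assay on HEK385-7 cells for displacement of a labelled ligand from prostaglandin D2 receptor 2 (Homo sapiens); a higher number here means a weaker inhibitor, a lower number a stronger inhibitor. Compound 2, `O=C(O)Cc1sc(C(c2ccccc2)c2ccccc2)nc1-c1cccc(F)c1`, gives 2.9 nM. Compound 3, `O=C(O)Cc1sc(C(c2ccccc2)c2ccccc2)nc1-c1ccc(F)c(F)c1`, gives 4.1 nM.

Compound 3 stands second highest of the three numbers; its step of a 1.4-fold higher number from compound 2 to compound 3 (0.15 log units; within the scatter) lies within the scatter, while a 2.1-fold lower number from compound 1 to compound 3 (0.33 log units; beyond the scatter) lies beyond it. Compound 4, `O=C(O)Cc1sc(C(c2ccccc2)c2ccccc2)nc1-c1ccc(C(F)(F)F)cc1`, differs from compound 3 by 4-(trifluoromethyl)phenyl in place of 3,4-difluorophenyl on an aromatic carbon. Among the compounds with values here, only a 2.1-fold lower number from compound 1 to compound 3 (0.33 log units; beyond the scatter) bears on this change, since removing the fluoro that compound 3 carries over compound 1 reverses that modest step; the trifluoromethyl itself has no measured precedent here. A small upward step is therefore expected, a 1.7-fold higher number from compound 3 to compound 4 (0.23 log units; within the scatter), giving an estimate for compound 4 of 7 nM, with a range from 2.5 nM to 20 nM.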

Compound 4, half-maximal inhibitory concentration: 1100 nM
Estimate against measurement, compound 4: 160-fold (2.20 log units) below; measured number above the stated range.
By their numbers in this assay, from the lowest: compounds 2 and 3 (each within the scatter of the next); then compound 1; then compound 4.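

Among the first three compounds, changing the fluorine pattern on this aromatic ring produced only small differences. Replacing the ring with 4-(trifluoromethyl)phenyl produces a far larger loss of potency (a 270-fold higher number from compound 3 to compound 4 (2.43 log units; beyond the scatter); a 380-fold higher number from compound 2 to compound 4 (2.58 log units; beyond the scatter)). Even the single swap of trifluoromethyl for fluoro gives a large step (a 130-fold higher number from compound 1 to compound 4 (2.10 log units; beyond the scatter)), so this position does not tolerate every fluorinated group equally. Nothing measured here explains the loss. From the compounds shown here alone, it remains open whether a methyl or a chloro in place of the trifluoromethyl would keep the number low or share the loss.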